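The compounds below may be only part of what the source reports. "The series", "measured", "known", "first", "only" and "open" are said of these compounds alone.

Measured in an ADME assay on MDBK cells (Bos taurus) for cytotoxicity, read by MTT assay, with a stated time of 96 h; on this read-out lower numbers stand for higher toxicity in this test and higher numbers for lower toxicity in this test:
- Compound 1 `O=C(NC(=S)Nc1cccc(C(F)(F)F)c1)c1ccccc1`: > 100000 nM
- Compound 2 `O=[N+]([O-])c1ccc(NC(=S)Nc2cccc(C(F)(F)F)c2)cc1`: 10000 nM
- Compound 3 `COc1cccc(NC(=S)Nc2cccc(C(F)(F)F)c2)c1`: 52000 nM

Compound 1 has the entry > 100000 nM, which is a limit and not a number. Compound 3 has the higher of the two true numbers, and the gap down to compound 2 lies beyond the usual scatter. Compound 4 `FC(F)(F)c1cccc(NC(=S)Nc2cccc(Br)c2)c1` has bromo in place of methoxy on an aromatic carbon, meta to a large group: bromo in place of methoxy on an aromatic carbon. Among the compounds with values here, no measured pair shows this swap, so the only guide is the span from compound 2 at 10000 nM to compound 3 at 52000 nM. A modest step to a lower number is expected, a 2.6-fold lower number from compound 3 to compound 4 (0.41 log units; beyond the scatter). For compound 4 the estimate is 20000 nM, with an expected range of 7000 nM to 60000 nM.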

Compound 4, half-maximal cytotoxic concentration: 10000 nM
Compound 4: the middle estimate sits 2.0-fold (0.30 log units) above what was measured, and the stated range covers the measured number.
By their numbers in this assay, from the lowest: compounds 2 and 4 (each within the scatter of the next); then compound 3. At a limit, above all of these: compound 1.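

Within the data shown here, compound 3 and compound 4 form the first pair that differs in one place only. In this assay, bromo in place of methoxy on an aromatic carbon, meta to a large group, gives a 5.2-fold lower number from compound 3 to compound 4 (0.72 log units; beyond the scatter), so this position can change the number, and this swap brings higher toxicity in this test. Nothing measured here explains why the number moves.

Still open, as far as these compounds go, is how an amine, a carboxylic acid or a chloro group at the same place would compare. Also open, from the compounds shown here alone, is whether the same swap would have a similar effect on another part of the core.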